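This account rests on a few compounds, and the source may have more. Where it says the series, first, only, none or still open, it means among the compounds named here.

Compound 1 `O=c1cc(-c2ccccc2)oc2cc(O)c(OCCCCN3CCCCC3)c(O)c12` and compound 2 `CN1CCN(CCCCOc2c(O)cc3oc(-c4ccccc4)cc(=O)c3c2O)CC1` share one core and differ only in the ring at the end of the chain. In a functional assay on A549 cells (Homo sapiens) for antiproliferative activity, read by MTT assay, with a stated time of 48 h (a lower number here means a stronger inhibitor, a higher number a weaker inhibitor), compound 1 gives 75000 nM. Compound 2 reaches only a limit of this assay, > 100000 nM, as the limit of > 100000 nM in this assay, at which 1 of the 2 values shown sits, records. The step of an at least 1.3-fold higher number from compound 1 to compound 2 (0.12 log units; that floor lies within the scatter) lies within the usual scatter. Compound 3 `O=c1cc(-c2ccccc2)oc2cc(O)c(OCCCCN3CCCC3)c(O)c12` carries the change (pyrrolidin-1-yl in place of 4-methylpiperazin-1-yl on a saturated chain carbon, four bonds along the chain from an oxygen on an aromatic ring). Within the data shown here, only that one measured step bears on this change, and it was small; a step of similar size, without a clear direction, is therefore expected, an at least 1.2-fold lower number from compound 2 to compound 3 (0.09 log units; that floor lies within the scatter). Compound 3 is estimated at 80000 nM, expected between 30000 nM and 200000 nM.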

Compound 3, half-maximal inhibitory concentration: 51000 nM
Compound 3: middle estimate off by 1.6-fold (0.20 log units), on the high side; measured number inside the range.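

The new comparison is a 1.5-fold lower number from compound 1 to compound 3 (0.17 log units; within the scatter), so pyrrolidin-1-yl and piperidin-1-yl at the end of this chain cannot be told apart in this assay. The other new step is an at least 1.9-fold lower number from compound 2 to compound 3 (0.29 log units; that floor lies within the scatter), which gives only a floor for the change from 4-methylpiperazin-1-yl. Compound 2 has a limit of the assay and not a number, so the true size of that step stays unknown: the limit of > 100000 nM in this assay, at which 1 of the 3 values shown sits.

Going by these compounds, whether a morpholine ring or an open-chain amine such as diethylamino at the chain end would shift the number remains open. So does the effect of a shorter or longer chain.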